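This account rests on a few compounds, and the source may have more. Where it says the series, first, only, none or still open, it means among the compounds named here.

Working notes on the aldehyde series. Compound 1 `O=C[C@H](C[C@@H]1CCNC1=O)NC(=O)[C@H](CC1CCCCC1)NC(=O)c1cc2ccccc2[nH]1` gives > 100000 nM in a toxicity assay on L929 cells (Mus musculus) for cytotoxicity (on this read-out lower numbers stand for higher toxicity in this test and higher numbers for lower toxicity in this test), a limit and not a number. Compound 2 `CCCCC1CCC(OC(=O)N[C@@H](CC(C)C)C(=O)N[C@H](C=O)C[C@@H]2CCNC2=O)CC1` gives 63300 nM in this assay. Compound 3 `CCCC1CCC(OC(=O)N[C@@H](CC(C)C)C(=O)N[C@H](C=O)C[C@@H]2CCNC2=O)CC1` gives > 100000 nM in this assay, again a limit and not a number. Compound 3 thus stands at the limit of > 100000 nM in this assay, at which 2 of the 3 values shown sit. Among the measured compounds shown here, the one measured step, an at least 1.5-fold higher number from compound 2 to compound 3 (0.19 log units; that floor lies within the scatter), runs toward that limit. Compound 4 `CC(C)C[C@H](NC(=O)OC1CCCCC1)C(=O)N[C@H](C=O)C[C@@H]1CCNC1=O` is not yet measured and differs from compound 3 by hydrogen in place of propyl on a saturated ring carbon, a change in the same direction as the measured step, only larger. In this assay compound 4 is expected to show a step that the limit leaves unreadable from compound 3 to compound 4, most likely remaining at the limit. Compound 4 is estimated at 150000 nM, within 50000 nM to 500000 nM.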

Compound 4, half-maximal cytotoxic concentration: > 100000 nM
Compound 4: no number, only a limit; the forecaster's own chance of this, stated with the estimate: 70%; the middle value lies beyond the limit too.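

Going from 4-propylcyclohexyl to cyclohexyl shows that this ring carbon needs no chain at all for the read-out in this assay to stay at its limit, and the step between compound 3 and compound 4 cannot be read, as both values are limits. Hydrogen in place of butyl at the same ring carbon gives an at least 1.5-fold higher number from compound 2 to compound 4 (0.19 log units; that floor lies within the scatter). With propyl and with hydrogen alike, the series rests at one value: the limit of > 100000 nM in this assay, at which 3 of the 4 values shown sit.

Going by these compounds, compound 2 alone carries a number, so how far the other compounds lie past the limit stays open. Also open, on these data alone, is whether an amine, a carboxylic acid or a chain longer than butyl on this ring carbon would give a lower number.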